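This account rests on a few compounds, and the source may have more. Where it says the series, first, only, none or still open, it means among the compounds named here.

Working notes on the series. Compound 1 `COc1ccc(-c2cc(/C=C/C(=O)c3ccc(OC)c(OC)c3)[nH]n2)cc1` and compound 2 `COc1ccc(C(=O)/C=C/c2cc(-c3cc(OC)c(OC)c(OC)c3)n[nH]2)cc1` share a core and differ in the placement of the aryl groups around the chain. In a functional assay on IGROV-1 cells (Homo sapiens) for inhibition, read by sulforhodamine B assay, with a stated time of 48 h (a higher number here means a weaker inhibitor of growth, a lower number a stronger inhibitor of growth), compound 1 gives 1570 nM. In this assay compound 2 gives 2210 nM; the two numbers lie within the usual scatter of each other, so no ordering between compound 1 and compound 2 can be read from them.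

Compound 3 `COc1cc(-c2cc(/C=C/C(=O)c3ccc(F)c(F)c3)[nH]n2)cc(OC)c1OC` follows from compound 2 by a single change: 3,4-difluorophenyl in place of 4-methoxyphenyl on a carbonyl carbon. For the measured compounds named here, no measured pair in the set shows the effect of such a swap, so there is no step to lean on. The expectation is that the change leaves the growth-inhibition number close to where compound 2 stands, with any movement most likely inside the scatter, as a 1.1-fold higher number from compound 2 to compound 3 (0.05 log units; within the scatter) expresses. Compound 3 is therefore estimated at 2500 nM in this assay, with a range from 900 nM to 7000 nM.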

Compound 3, concentration for 50% growth inhibition: 3620 nM
Compound 3: the middle estimate sits 1.4-fold (0.16 log units) below what was measured, and the stated range covers the measured number.
By their numbers in this assay, from the lowest: compounds 1, 2 and 3 (each within the scatter of the next, the first and the last beyond it).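

For the compounds shown here, this is the first step at this position, on a carbonyl carbon whose other neighbour is a double-bonded chain carbon. In this assay, the swap of 4-methoxyphenyl for 3,4-difluorophenyl gives a 1.6-fold higher number from compound 2 to compound 3 (0.21 log units; within the scatter), so this exchange of one carbon-only aromatic ring for another, which takes away the single hydrogen-bond acceptor counted on the leaving group, does not separate the two compounds. Nothing available bears on a reason for this result.

Going by these compounds alone, the step covers only two substituted phenyl groups, so it remains open how a group of another kind at this carbonyl carbon, such as a simple alkyl amine or a phenyl ring carrying a carboxylic acid, would read in this assay. Going by these compounds, the same swap on the core of compound 1 also remains open.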